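Swapping fluoro for methoxy on the benzyl ring

The source may hold more compounds than are shown below. What is called first, only, known or untested is meant among the compounds shown, and "the series" means these compounds.

Measured so far:
compound 1 `COc1ccc(CNc2nc3cc(N)cc(N)c3nc2-c2ccccc2)cc1OC`: 10000 nM
compound 2 `Nc1cc(N)c2nc(-c3ccccc3)c(NCc3ccc(F)cc3)nc2c1`: 1860 nM

In a functional assay on SK-MEL-5 cells (Homo sapiens) for inhibition, read by sulforhodamine B assay, with a stated time of 48 h (on this read-out lower numbers stand for stronger inhibition of growth and higher numbers for weaker inhibition of growth), compound 2 gives the lowest of the two numbers; compound 1 sits higher by a 5.4-fold lower number from compound 1 to compound 2 (0.73 log units; beyond the scatter). Compound 3 `COc1ccc(CNc2nc3cc(N)cc(N)c3nc2-c2ccccc2)cc1` differs from compound 2 by methoxy in place of fluoro on an aromatic carbon of a six-membered aromatic ring of carbon only. Within the data shown here, the one measured step shows that moving from fluoro toward methoxy groups on this ring raised the number, so compound 3 is expected to give a number between those of compound 2 and compound 1, estimated at 4000 nM (range 1500 nM to 12000 nM), a step of a 2.2-fold higher number from compound 2 to compound 3 (0.33 log units; beyond the scatter).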

Compound 3, concentration for 50% growth inhibition: 17800 nM
Compound 3: middle estimate off by 4.5-fold (0.65 log units), on the low side; the whole stated range lies below it.
By their numbers in this assay, from the lowest: compound 2; then compounds 1 and 3 (each within the scatter of the next).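

In this assay, the swap of fluoro for methoxy at this ring carbon alone gives a 9.6-fold higher number from compound 2 to compound 3 (0.98 log units; beyond the scatter), so the single methoxy is enough to separate compound 3 clearly from compound 2. The further methoxy of compound 1 adds no readable difference, since a 1.8-fold higher number from compound 1 to compound 3 (0.25 log units; within the scatter) stays within the scatter. Nothing available explains why methoxy and fluoro differ here.

Open is whether fluoro itself matters or methoxy is the problem, since no compound shown has plain hydrogen at this carbon. Chloro or an amine there would also help to tell.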